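Replacing one 3-nitrophenyl group of compound 3

The source may hold more compounds than are shown below. What is called first, only, known or untested is meant among the compounds shown, and "the series" means these compounds.

Within the data shown here, in a functional assay on SMMC-7721 cells (Homo sapiens) for cytotoxicity, read by MTT assay, with a stated time of 24 h (a lower number here means a stronger inhibitor, a higher number a weaker inhibitor), compound 3 (`CC(=O)Nc1ccc(S(=O)(=O)N2C/C(=C\c3cccc([N+](=O)[O-])c3)C(=O)/C(=C/c3cccc([N+](=O)[O-])c3)C2)cc1`) gives 8420 nM and holds the highest of the three numbers so far. Compound 1 (`O=C1/C(=C/c2cccc([N+](=O)[O-])c2)CN(S(=O)(=O)c2ccc(F)cc2)C/C1=C\c1cccc([N+](=O)[O-])c1`) gives 3980 nM and compound 2 (`COc1cc(/C=C2\CN(S(=O)(=O)c3ccc(F)cc3)C/C(=C\c3cc(OC)c(OC)c(OC)c3)C2=O)cc(OC)c1OC`) gives 3840 nM and these two values lie within the scatter of each other. Among the measured compounds shown here, the one measured step, a 2.1-fold higher number from compound 1 to compound 3 (0.33 log units; beyond the scatter) with acetamido in place of fluoro on an aromatic carbon, is modest and lies just beyond the scatter.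

Compound 4 (`CC(=O)Nc1ccc(S(=O)(=O)N2C/C(=C\c3cccc([N+](=O)[O-])c3)C(=O)/C(=C/c3ccccc3F)C2)cc1`) carries 2-fluorophenyl in place of 3-nitrophenyl on a double-bonded chain carbon bound to a double-bonded ring carbon. For the measured compounds named here, no measured step covers this place, so the evidence is indirect. The step from compound 1 to compound 3 sits elsewhere on the molecule and serves only as a guide to size. The near-identical values of compound 1 and compound 2 offer no clear direction. The expected step is a 1.2-fold lower number from compound 3 to compound 4 (0.08 log units; within the scatter) and stays inside the scatter, so no real shift is anticipated. Compound 4 is estimated at 7000 nM with 3000 nM to 16000 nM as the expected range.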

Compound 4, half-maximal inhibitory concentration: 10200 nM
Compound 4: the middle estimate sits 1.5-fold (0.16 log units) below what was measured; measured number inside the range.
By their numbers in this assay, from the lowest: compounds 2 and 1 (each within the scatter of the next); then compounds 3 and 4 (each within the scatter of the next).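

In this assay, the exchange at this place gives a 1.2-fold higher number from compound 3 to compound 4 (0.08 log units; within the scatter) and so leaves the number within the scatter. Among these compounds, this is the first reading at this position, as compound 1, compound 2 and compound 3 each carry the same group on both chain carbons, whereas compound 4 keeps 3-nitrophenyl on one and carries 2-fluorophenyl on the other. The swap removes a group of 9 heavy atoms with 2 hydrogen-bond acceptors and brings in one of 7 heavy atoms with 0 hydrogen-bond acceptors, so, for this single pair, neither the nitro group nor those acceptors are needed to hold the number where it stands. Nothing shown here gives a measured property that could account for this result.

Still open, from the compounds shown here alone, is whether this single exchange would read the same against the fluoro sulfonyl partner, compound 1, rather than the acetamido one, compound 3. A single pair also cannot show whether an amine or a carboxylic acid on the phenyl ring at this place, or a longer chain in place of the ring, would move the number beyond the scatter.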